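The compounds below may be only part of what the source reports. "The series", "measured", "known", "first", "only" and "open" are said of these compounds alone.

Measured so far:
compound 1 `O=C1C(=O)N(Cc2ccc(-c3ccncc3)nc2)c2ccc(OC(F)(F)F)cc21` – 4400 nM
compound 2 `O=C1C(=O)N(Cc2ccc(Oc3ccccn3)cc2)c2ccc(OC(F)(F)F)cc21` – 3200 nM

Both values come from a functional assay on CHO cells for positive allosteric modulation of muscarinic acetylcholine receptor M5 (Homo sapiens), read by FLIPR and calcium flux, with a stated time of 1 h; on this read-out higher numbers stand for an effect only at larger amounts of compound and lower numbers for an effect already at smaller amounts. Compound 1 carries the highest of the two numbers, but compound 2 sits within the scatter of it, so the pair is not separated. Compound 3 `O=C1C(=O)N(Cc2ccc(-c3ccccc3)nc2)c2ccc(OC(F)(F)F)cc21` has not been measured. It differs from compound 1 in one place: phenyl in place of pyridin-4-yl on an aromatic carbon. Among the measured compounds shown here, no step between measured compounds bears on this change, so no direction beyond the scatter is expected. For compound 3 the estimate is 3500 nM, with a range of 1200 nM to 10000 nM. The expected step of a 1.3-fold lower number from compound 1 to compound 3 (0.10 log units; within the scatter) is small and may be nothing beyond the scatter.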

Compound 3, half-maximal effective concentration: 3800 nM
Compound 3: the middle estimate sits 1.1-fold (0.04 log units) below what was measured; the measured number falls inside the stated range.
By their numbers in this assay, from the lowest: compounds 2, 3 and 1 (each within the scatter of the next).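

In this assay, phenyl in place of pyridin-4-yl on the aromatic carbon next to the ring nitrogen gives a 1.2-fold lower number from compound 1 to compound 3 (0.06 log units; within the scatter) and leaves the two compounds unseparated. At this position, an all-carbon six-membered aromatic ring therefore reads the same as one with a ring nitrogen and its hydrogen-bond acceptor. No available measurement explains this outcome.

From the compounds shown here alone, it remains open whether a non-aromatic group here, such as an amine or a carboxylic acid, would read differently. Going by these compounds, the effect of a fluorine or methoxy substituent on the phenyl also remains open.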